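From ethoxycarbonyl to nitro at the assay limit

A few compounds are considered here, and "the series" means these few. Any claim that something is new, unique, unknown or untested is made for them only; others in the source may bear on it.

Measured in a functional assay (plasma) for inhibition, with Oryctolagus cuniculus as the target; a higher number here means that more compound is needed for the effect, a lower number that less compound is needed:
- compound 1 `CCOC(=O)c1c(C)cc2cnn(-c3cccc(OC)c3)c(=O)c2c1C`: >= 50 uM
- compound 2 `CCOC(=O)c1ccc(-n2ncc3cc(C)c(C(=O)OCC)c(C)c3c2=O)cc1`: >= 50 uM

Each entry is a limit of the assay and not a number. Compound 2 therefore stands only at the limit of >= 50 uM. Compound 3 `CCOC(=O)c1c(C)cc2cnn(-c3ccc([N+](=O)[O-])cc3)c(=O)c2c1C` differs from it by nitro in place of ethoxycarbonyl on an aromatic carbon, with nitro in place of ethoxycarbonyl on an aromatic carbon, para to a large group. Among the compounds with values here, no measured step shows the size of such a change, so no step beyond the scatter is expected in this assay. The estimate means a number no higher from compound 2 to compound 3 (the limit leaves the size open). Compound 3 is expected at 50 uM, with an estimated range of 20 uM to 100 uM.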

Compound 3, concentration for half-maximal effect: >= 50 uM
Compound 3: no number, only a limit (the forecaster's own chance of this, stated with the estimate: 80%); the middle value sits exactly at the limit.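

No step can be read between compound 1, compound 2 and compound 3 in this assay, as each entry is only a limit: the limit of >= 50 uM in this assay, at which 3 of the 3 values shown sit.

The compounds shown leave open whether nitro in place of ethoxycarbonyl changes the concentration needed at all.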